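Pyridinyl isomer step from compound 3 to compound 4

The source may hold more compounds than are shown below. What is called first, only, known or untested is meant among the compounds shown, and "the series" means these compounds.

In a functional assay on A-375 cells (Homo sapiens) for activation, with a stated time of 3 days (on this read-out higher numbers stand for an effect only at larger amounts of compound and lower numbers for an effect already at smaller amounts), compound 3 `O=C(Nc1ccc(-c2ccncc2)cc1)C1CCCN(Cc2ccc(F)c(F)c2)C1` gives 1180 nM, within the scatter of compound 1 `O=C(Nc1ccc(-c2cscn2)cc1)C1CCCN(Cc2ccc(F)c(F)c2)C1` at 1240 nM and of compound 2 `O=C(Nc1ccc(-c2cscn2)cc1)C1CCCN(Cc2cc(F)cc(F)c2)C1` at 1500 nM. Compound 4 `O=C(Nc1ccc(-c2ccccn2)cc1)C1CCCN(Cc2ccc(F)c(F)c2)C1` carries pyridin-2-yl in place of pyridin-4-yl on an aromatic carbon. The nearest evidence is a 1.1-fold lower number from compound 1 to compound 3 (0.02 log units; within the scatter), where pyridin-4-yl replaces 1,3-thiazol-4-yl at the same place. The exchange of 3,4-difluorophenyl for 3,5-difluorophenyl, a 1.2-fold higher number from compound 1 to compound 2 (0.08 log units; within the scatter), is also small. Neither step tests pyridin-2-yl directly, so no shift beyond the scatter is expected in this assay. The expected change is a 1.0-fold higher number from compound 3 to compound 4 (0.01 log units; within the scatter). Compound 4 is estimated at 1200 nM, with an expected range of 600 nM to 2500 nM.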

Compound 4, half-maximal effective concentration: 11000 nM
The estimate for compound 4 lay 9.2-fold (0.96 log units) below the measured number; the measured number lies above the stated range.
By their numbers in this assay, from the lowest: compounds 3, 1 and 2 (each within the scatter of the next); then compound 4.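

At this place, on an aromatic carbon para to a large group, the choice of pyridine isomer matters in this assay: the exchange gives a 9.3-fold higher number from compound 3 to compound 4 (0.97 log units; beyond the scatter) even though pyridin-2-yl and pyridin-4-yl have the same atoms. Pyridin-2-yl also departs from 1,3-thiazol-4-yl, with an 8.9-fold higher number from compound 1 to compound 4 (0.95 log units; beyond the scatter), so the earlier match between 1,3-thiazol-4-yl and pyridin-4-yl does not extend to every six-membered or five-membered aromatic group here. Nothing available explains this shift.

Where pyridin-3-yl would fall relative to these isomers remains open. Also open, as far as these compounds go, is whether an amine or methyl group on pyridin-2-yl, or 3,5-difluorophenyl in place of 3,4-difluorophenyl, would change the size of the step.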